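Replacing the Dichlorophenyl of Compound 1 with Cycloheptyl

The source may report more compounds than this note shows. Statements on the series, on what has been measured and on what is new or still open speak of the compounds shown alone.

Three compounds have been measured in a functional assay on CHO cells with adenosine receptor A1 (Homo sapiens) as the target, read by cAMP accumulation and immunoassay, with a stated time of 6 min, tested at 10 uM; on this read-out higher numbers stand for a weaker effect at the one concentration tested and lower numbers for a stronger effect:
compound 1 `Nc1scc(CN2CCN(c3ccc(Cl)cc3Cl)CC2)c1C(=O)c1ccc(Cl)cc1`, -74%
compound 2 `Nc1scc(CN2CCN(c3ccc([N+](=O)[O-])cc3)CC2)c1C(=O)c1ccc(Cl)cc1`, -17%
compound 3 `Nc1scc(CN2CCN(c3ccncc3)CC2)c1C(=O)c1ccc(Cl)cc1`, -15%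

Compound 1 stands lowest of the three in this assay; compound 2 lies nearest and compound 3 furthest, both higher and both beyond the scatter. Compound 4 `Nc1scc(CN2CCN(C3CCCCCC3)CC2)c1C(=O)c1ccc(Cl)cc1` has not been measured. It differs from compound 1 in one place: cycloheptyl in place of 2,4-dichlorophenyl on an amine nitrogen in a ring. Within the data shown here, no measured step involves a cycloheptyl, so the nearest comparisons are the two other replacements of the same 2,4-dichlorophenyl, a number 57 percentage points higher from compound 1 to compound 2 (beyond the scatter) and a number 59 percentage points higher from compound 1 to compound 3 (beyond the scatter), both large rises. Between those two products the step was small, a number 2 percentage points higher from compound 2 to compound 3 (within the scatter). Compound 4 is therefore expected to show a rise of similar kind, a number 49 percentage points higher from compound 1 to compound 4 (beyond the scatter). The estimate for compound 4 is -25%, expected to fall between -60% and 10%.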

Compound 4, a percentage reported as activity, at one concentration (the size of the read-out at that concentration, not a potency): -25%
The estimate for compound 4 equals the measured number at the digits printed; measured number inside the range.
By their numbers in this assay, from the lowest: compound 1; then compounds 4, 2 and 3 (each within the scatter of the next).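

Cycloheptyl on the amine nitrogen in a ring gives a number 49 percentage points higher from compound 1 to compound 4 (beyond the scatter) in this assay, so a carbon-only non-aromatic ring joins the two aromatic replacements, with a number 10 percentage points lower from compound 3 to compound 4 (within the scatter) and a number 8 percentage points lower from compound 2 to compound 4 (within the scatter) in the same group. Among these four compounds, then, only 2,4-dichlorophenyl stands apart, whether the group entering in its place is aromatic or not.

The compounds shown leave open whether a plain phenyl, a 4-chlorophenyl or a cyclohexyl here would stay with compound 1 or with the other three. Nothing measured here accounts for these steps.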